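Swapping the amide cap on a hydroxamic acid chain

This account rests on a few compounds, and the source may have more. Where it says the series, first, only, none or still open, it means among the compounds named here.

Three compounds share one core and differ only in the group on the amide-type nitrogen. In a functional assay on NFF cells (Homo sapiens) for antiproliferative activity (on this read-out lower numbers stand for stronger inhibition and higher numbers for weaker inhibition), compound 1 `CN(C)c1ccc(NC(=O)[C@H](CCCCCC(=O)NO)NC(=O)OCc2ccccc2)cc1` gives 650 nM, compound 2 `O=C(CCCCC[C@H](NC(=O)OCc1ccccc1)C(=O)NCc1ccncc1)NO` gives 23300 nM, and compound 3 `O=C(CCCCC[C@H](NC(=O)OCc1ccccc1)C(=O)Nc1ccc(-c2ccccc2)cc1)NO` gives 2200 nM. Compound 3 thus stands second highest of the three, since the number is a 3.4-fold higher number from compound 1 to compound 3 (0.53 log units; beyond the scatter) and an 11-fold lower number from compound 2 to compound 3 (1.02 log units; beyond the scatter).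

Compound 4 `O=C(CCCCC[C@H](NC(=O)OCc1ccccc1)C(=O)NC1CCCc2ccccc21)NO` is not yet measured. Its change from compound 3 is 1,2,3,4-tetrahydronaphthalen-1-yl in place of 4-phenylphenyl on an amide-type nitrogen. Among the compounds with values here, no measured step makes exactly this exchange. The two steps that bear on it both alter the same amide-type nitrogen: the number was a 36-fold higher number from compound 1 to compound 2 (1.55 log units; beyond the scatter) and an 11-fold lower number from compound 2 to compound 3 (1.02 log units; beyond the scatter), showing that this position moves the read-out strongly. Since the entering group, like the (pyridin-4-yl)methyl of compound 2, is not made of aromatic rings alone, compound 4 is expected to give a higher number than compound 3. Compound 4 is estimated at 6000 nM, with a range from 1500 nM to 25000 nM, an expected step of a 2.7-fold higher number from compound 3 to compound 4 (0.44 log units; beyond the scatter).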

Compound 4, half-maximal inhibitory concentration: 1700 nM
Compound 4: the middle estimate sits 3.5-fold (0.55 log units) above what was measured; the range from low to high includes it.
By their numbers in this assay, from the lowest: compound 1; then compounds 4 and 3 (each within the scatter of the next); then compound 2.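

In this assay there is a 1.3-fold lower number from compound 3 to compound 4 (0.11 log units; within the scatter), so a group with one non-aromatic and one aromatic ring, 1,2,3,4-tetrahydronaphthalen-1-yl, reads the same as 4-phenylphenyl with its two aromatic rings. A group that is not made of aromatic rings alone therefore need not bring the weak read-out seen with (pyridin-4-yl)methyl, as there is a 14-fold lower number from compound 2 to compound 4 (1.14 log units; beyond the scatter). The 4-(dimethylamino)phenyl group still gives the lowest number of the set, with a 2.6-fold higher number from compound 1 to compound 4 (0.42 log units; beyond the scatter).

Nothing available here explains these differences. On these data alone, it remains open how the read-out would respond to a primary amine or a carboxylic acid on the aromatic ring of the 1,2,3,4-tetrahydronaphthalen-1-yl group, or to a simple cyclohexyl group on the same nitrogen.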